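The source may report more compounds than this note shows. Statements on the series, on what has been measured and on what is new or still open speak of the compounds shown alone.

Two compounds from this series carry a shared core with a propyl chain and a phenyl group, joined through a short linker to a piperazine that bears a second aromatic ring. Compound 1 `CCCc1nc(-c2ccccc2)c(CNCCCN2CCN(c3ccccc3)CC2)o1` has a three-carbon linker and an unsubstituted phenyl on the piperazine. In an assay on HEK293 cells for inhibition of Voltage-dependent T-type calcium channel subunit alpha-1G (Homo sapiens), read by fluorescence, tested at 10 uM (a higher number here means more inhibition at the concentration tested (going by the name of the read-out), a lower number less inhibition), compound 1 gives 43.7%. Compound 2 `CCCc1nc(-c2ccccc2)c(CNCCN2CCN(c3ccc(C)cc3)CC2)o1` shortens the linker by one carbon and adds a methyl on the phenyl of the piperazine. In this assay compound 2 gives 48.1%, a number lying within the usual scatter of compound 1, so the two cannot be told apart on these data.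

Compound 3 `CCCc1nc(-c2ccccc2)c(CNCCN2CCN(c3ccccc3)CC2)o1` keeps the shorter linker of compound 2 but differs from it in one place: hydrogen in place of methyl on an aromatic carbon. Within the data shown here, no measured pair shows the effect of this change by itself. Given that compound 1 and compound 2 agree within scatter, the step from compound 2 to compound 3 is expected to be small, a number 4.1 percentage points lower from compound 2 to compound 3 (within the scatter), with no direction beyond the scatter. Compound 3 is therefore estimated to give about 44% in this assay, most likely between 30% and 58%.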

Compound 3, a percentage reported as inhibition, at one concentration (the size of the read-out at that concentration, not a potency): 54.3%
Beside the measured number, compound 3's estimate is 10.3 percentage points below it; measured number inside the range.
By their numbers in this assay, from the lowest: compounds 1, 2 and 3 (each within the scatter of the next, the first and the last beyond it).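

Among these compounds, this pair gives the first direct reading of the methyl group on its own: going from 4-methylphenyl to phenyl gives a number 6.2 percentage points higher from compound 2 to compound 3 (within the scatter) in this assay. At this place on the aromatic ring, para to a large group, methyl and hydrogen therefore cannot be told apart on these data, and this one pair gives no sign that the methyl matters for the read-out. No measurement shown here bears on the reason for this result.

From the compounds shown here alone, it remains open whether a chlorine, a methoxy group or a longer chain such as ethyl at the same place would give a step beyond the scatter. Each number is also a reading at a single concentration, which leaves potency itself open.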